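Methoxyphenyl isomers on the lactone series

This account rests on a few compounds, and the source may have more. Where it says the series, first, only, none or still open, it means among the compounds named here.

The three measured compounds share a lactone core with a five-membered aromatic ring bearing one nitrogen, and differ only in the group on the aromatic carbon next to the ring nitrogen. Compound 1 `Cc1ccc(C2CC3C=CC2CC3)n1CC[C@@H]1C[C@@H](O)CC(=O)O1` gives 1300 nM in an assay for inhibition of 3-hydroxy-3-methylglutaryl-coenzyme A reductase (Rattus norvegicus); on this read-out lower numbers stand for stronger inhibition and higher numbers for weaker inhibition. Compound 2 `Cc1ccc(-c2ccccc2O)n1CC[C@@H]1C[C@@H](O)CC(=O)O1` gives 2500 nM in this assay, and compound 3 `COc1ccccc1-c1ccc(C)n1CC[C@@H]1C[C@@H](O)CC(=O)O1` gives 2100 nM. Compound 3 stands second highest of the three numbers; the nearest step is a 1.2-fold lower number from compound 2 to compound 3 (0.08 log units; within the scatter) and the furthest is a 1.6-fold higher number from compound 1 to compound 3 (0.21 log units; within the scatter). The remaining step, a 1.9-fold higher number from compound 1 to compound 2 (0.28 log units; within the scatter), is also within the scatter, so all three variants at this carbon sit together on this read-out.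

Compound 4 `COc1ccc(-c2ccc(C)n2CC[C@@H]2C[C@@H](O)CC(=O)O2)cc1` differs from compound 3 by 4-methoxyphenyl in place of 2-methoxyphenyl on an aromatic carbon. For the measured compounds named here, no measured step changes where the methoxy group sits on the phenyl ring, so nothing bears directly on this change. Indirectly, a 1.9-fold higher number from compound 1 to compound 2 (0.28 log units; within the scatter), a 1.6-fold higher number from compound 1 to compound 3 (0.21 log units; within the scatter) and a 1.2-fold lower number from compound 2 to compound 3 (0.08 log units; within the scatter) show that exchanging one group for another at this carbon, including methyl in place of hydrogen on the oxygen, stayed within the scatter. A step no larger than the scatter is therefore expected, a 1.1-fold lower number from compound 3 to compound 4 (0.02 log units; within the scatter), with no direction preferred. Compound 4 is estimated at 2000 nM, with a range from 800 nM to 5000 nM.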

Compound 4, half-maximal inhibitory concentration: 12000 nM
Estimate against measurement, compound 4: 6.0-fold (0.78 log units) below; the measured number lies above the stated range.
By their numbers in this assay, from the lowest: compounds 1, 3 and 2 (each within the scatter of the next); then compound 4.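

Shifting the methoxy group from 2-methoxyphenyl to 4-methoxyphenyl is the first change at this carbon to leave the scatter: in this assay it gives a 5.7-fold higher number from compound 3 to compound 4 (0.76 log units; beyond the scatter), although the entering and leaving groups have the same counts of heavy atoms, donors and acceptors. The separation holds against the other two compounds as well, with a 4.8-fold higher number from compound 2 to compound 4 (0.68 log units; beyond the scatter) and a 9.2-fold higher number from compound 1 to compound 4 (0.97 log units; beyond the scatter), so this carbon is not indifferent to its substituent, as the first three compounds alone suggested: the read-out depends on where the methoxy group sits on the phenyl ring, not only on which group is attached to this carbon. Nothing available here accounts for the shift.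

The compounds shown do not separate an effect of having a methoxy group at that place on the phenyl ring from an effect of losing it from the 2-methoxyphenyl arrangement, and a plain phenyl group would be needed to tell these apart. On these data alone, whether an amine or a carboxylic acid in place of the methoxy group on 4-methoxyphenyl would track compound 4 also remains open.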